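Methyl in Place of Trifluoromethyl on the Shared Core

The source may hold more compounds than are shown below. What is called first, only, known or untested is meant among the compounds shown, and "the series" means these compounds.

Compound 1 `C[C@H](NC(=O)c1c(C(F)(F)F)nnn1Cc1ccc(C(F)(F)F)cc1)c1ccc(C(=O)O)cc1`: 225 nM
Compound 2 `C[C@H](NC(=O)c1c(C(F)(F)F)nnn1Cc1cccc(C(F)(F)F)c1)c1ccc(C(=O)O)cc1`: 1970 nM

In a functional assay on CHO cells for antagonist activity at prostaglandin E2 receptor EP4 subtype (Homo sapiens), read by calcium flux, with a stated time of 15 min (a lower number here means a stronger inhibitor, a higher number a weaker inhibitor), compound 1 gives 225 nM and stands as the lower of the two measured numbers; compound 2 gives 1970 nM. Among the measured compounds shown here, the single measured step, an 8.8-fold higher number from compound 1 to compound 2 (0.94 log units; beyond the scatter), concerns only the benzyl group and leaves the rest of the shared core untouched.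

Compound 3 `Cc1nnn(Cc2ccc(C(F)(F)F)cc2)c1C(=O)N[C@@H](C)c1ccc(C(=O)O)cc1` differs from compound 1 by methyl in place of trifluoromethyl on an aromatic carbon. For the measured compounds named here, no measured step touches this part of the core, so the step from compound 1 to compound 2 does not bear on the change, and the data give no direct guide to its size or direction. The expectation therefore rests on the value of compound 1 alone, with a wide range around it. Compound 3 is expected to give about 600 nM in this assay, within 150 nM to 3000 nM. That estimate corresponds to a 2.7-fold higher number from compound 1 to compound 3 (0.43 log units; beyond the scatter).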

Compound 3, half-maximal inhibitory concentration: > 10000 nM
Compound 3: a limit, no number; the forecaster's own chance of this, stated with the estimate: 5%; middle value at least 16-fold (1.22 log units) from the limit.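

The aromatic carbon two ring bonds from the ring atom that bears a 4-(trifluoromethyl)benzyl group proves sensitive to what it carries: methyl in place of trifluoromethyl gives an at least 44-fold higher number from compound 1 to compound 3 (1.64 log units; beyond the scatter). Among the compounds shown here, the earlier step concerned only the benzyl group, so this is the first sign that the group on this carbon of the shared core also matters for activity. Compound 3 has a limit in this assay, not a number: the limit of > 10000 nM in this assay, at which 1 of the 3 values shown sits.

From the compounds shown here alone, the true size of the step stays open. The data do not explain the loss of activity. Also open, going by these compounds, is whether ethyl, chlorine or a nitrile on this carbon would come closer to compound 1, and whether the same change would count as heavily with the 3-(trifluoromethyl)phenyl group of compound 2.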